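Swapping one aromatic group: compound 2 to compound 4

The source may report more compounds than this note shows. Statements on the series, on what has been measured and on what is new or still open speak of the compounds shown alone.

Measured in an ADME assay on L6 cells (Rattus norvegicus) for cytotoxicity, read by resazurin assay, with a stated time of 70 h; on this read-out higher numbers stand for weaker inhibition and lower numbers for stronger inhibition:
- compound 1 `COc1cccc(COc2ccc3c(c2)C(C)=CC(C)(C)N3Cc2cccc(OC)c2)c1`: > 210000 nM (a limit of the assay)
- compound 2 `CC(=O)Oc1ccc2c(c1)C(C)=CC(C)(C)N2Cc1ccc(C)cc1`: 21000 nM
- compound 3 `CC(=O)Oc1ccc2c(c1)C(C)=CC(C)(C)N2Cc1ccc(C(F)(F)F)cc1`: 14000 nM

For the measured compounds named here, compound 2, at 21000 nM, has only one neighbour with a real number: a 1.5-fold lower number from compound 2 to compound 3 (0.18 log units; within the scatter). Compound 1 reports only a limit, > 210000 nM. Compound 4 `COc1cccc(CN2c3ccc(OC(C)=O)cc3C(C)=CC2(C)C)c1` is still unmeasured, and it differs from compound 2 as follows: 3-methoxyphenyl in place of 4-methylphenyl on a saturated chain carbon bound to a nitrogen on an aromatic ring in a ring. In words, 3-methoxyphenyl stands in place of 4-methylphenyl on a saturated chain carbon bound to a nitrogen on an aromatic ring in a ring.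

Going by the values given here, the one measured step that bears on this also alters the 4-methylphenyl group, and it stayed small: a 1.5-fold lower number from compound 2 to compound 3 (0.18 log units; within the scatter). No step beyond the scatter is therefore expected in this assay, in either direction. The expected change is a 1.1-fold lower number from compound 2 to compound 4 (0.04 log units; within the scatter). For compound 4 the estimated value is 19000 nM, with an expected range of 8000 nM to 45000 nM.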

Compound 4, half-maximal inhibitory concentration: 29000 nM
Beside the measured number, compound 4's estimate is 1.5-fold (0.18 log units) below it; measured number inside the range.
By their numbers in this assay, from the lowest: compounds 3, 2 and 4 (each within the scatter of the next, the first and the last beyond it). At a limit, above all of these: compound 1.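

In this assay, a second swap of this aromatic group, now adding an oxygen, again leaves the number within the scatter (a 1.4-fold higher number from compound 2 to compound 4 (0.14 log units; within the scatter)). The change on the oxygen on an aromatic ring goes beyond the scatter, with acetyl in place of 3-methoxybenzyl (an at least 7.2-fold lower number from compound 1 to compound 4 (0.85 log units; beyond the scatter)). Compound 1 stands at a limit, so that step gives only a minimum size: the limit of > 210000 nM in this assay, at which 1 of the 4 values shown sits.

Still open, from the compounds shown here alone, is whether an amine or a carboxylic acid in place of the 3-methoxyphenyl would move the number beyond the scatter. Also open, going by these compounds, is how a longer acyl chain in place of acetyl would read.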